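The source may hold more compounds than are shown below. What is called first, only, known or untested is meant among the compounds shown, and "the series" means these compounds.

Measured in a functional assay on A549 cells (Homo sapiens) for antiproliferative activity, read by MTT assay, with a stated time of 72 h; a higher number here means a weaker inhibitor, a lower number a stronger inhibitor:
- compound 1 `CCOc1ccc(-c2ccc3ncn(-c4cc(OC)c(OC)c(OC)c4)c3c2)cc1`: 8550 nM
- compound 2 `COc1cc(-n2cnc3ccc(-c4ccc(C)cc4F)cc32)cc(OC)c1OC`: > 10000 nM (a limit of the assay, not a number)
- compound 3 `COc1cc(-n2cnc3ccc(-c4cccc([N+](=O)[O-])c4)cc32)cc(OC)c1OC`: 5410 nM

Compound 3 holds the lowest of the two numeric values, but compound 1 stands within the scatter of it: a 1.6-fold lower number from compound 1 to compound 3 (0.20 log units; within the scatter). No order is therefore claimed between them.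

Compound 4 `COc1cc(-n2cnc3ccc(-c4ccc(O)cc4)cc32)cc(OC)c1OC` carries 4-hydroxyphenyl in place of 3-nitrophenyl on an aromatic carbon.

Three measured steps exchange the group at this same carbon: a 1.6-fold lower number from compound 1 to compound 3 (0.20 log units; within the scatter), an at least 1.1-fold higher number from compound 1 to compound 2 (0.06 log units; that floor lies within the scatter) and an at least 1.8-fold lower number from compound 2 to compound 3 (0.26 log units; that floor lies within the scatter). All lie within the scatter, and the last two are floors only, so the true size of those two is open. None of them tests 4-hydroxyphenyl itself. With compound 3 at 5410 nM as the starting point, these steps give no ground to expect a large move in this assay.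

What is expected is a 1.1-fold higher number from compound 3 to compound 4 (0.04 log units; within the scatter), no step beyond the scatter. A reading reported only as a limit remains possible.

The estimate for compound 4 is 6000 nM, with an expected range of 2000 nM to 15000 nM.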

Compound 4, half-maximal inhibitory concentration: 5090 nM
For compound 4 the middle estimate is 1.2-fold (0.07 log units) above the measured one; the measured number falls inside the stated range.
By their numbers in this assay, from the lowest: compounds 4, 3 and 1 (each within the scatter of the next). At a limit, above all of these: compound 2.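

In this assay 4-hydroxyphenyl puts a hydrogen-bond donor on this carbon in place of 3-nitrophenyl, and the step stays within the scatter (a 1.1-fold lower number from compound 3 to compound 4 (0.03 log units; within the scatter)). Replacing the ethyl on the oxygen of 4-ethoxyphenyl with hydrogen also gives a step within the scatter (a 1.7-fold lower number from compound 1 to compound 4 (0.23 log units; within the scatter)). Compound 2 stands at a limit, not a number, so its step gives only a floor (an at least 1.9-fold lower number from compound 2 to compound 4 (0.29 log units; that floor lies within the scatter)) and its true size remains open: the limit of > 10000 nM in this assay, at which 1 of the 4 values shown sits.

As far as these compounds go, whether any group on this carbon can move the number beyond the scatter remains open; a phenyl ring bearing an amine, a carboxylic acid or a longer alkoxy chain would test this. The effect of moving the hydroxyl around the ring is also open, since 3-hydroxyphenyl lies outside the compounds shown.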